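The compounds below may be only part of what the source reports. "The series", "measured", "known", "first", "only" and "open" are said of these compounds alone.

Working notes on the series. Going by the values given here, in a toxicity assay on NIH3T3 cells (Mus musculus) for cytotoxicity, read by resazurin assay (on this read-out higher numbers stand for an effect only at larger amounts of compound and lower numbers for an effect already at smaller amounts), compound 1 `COC(=O)c1ccc(NCc2cncn2Cc2ccccc2C)cc1-c1ccccc1` gives 10000 nM, which is the only number recorded so far. Compound 2 `CNC(=O)c1ccc(NCc2cncn2Cc2ccc(-c3ccccc3)cc2)cc1-c1ccccc1` shows in this assay only a limit, > 1000 nM. Compound 3 `Clc1ccc(Cn2cncc2CNc2ccc(-c3nc4ccccc4s3)c(-c3ccccc3)c2)cc1` likewise shows only a limit, > 1000 nM. Beyond the single number of compound 1, the evidence is the limit of > 1000 nM in this assay, at which 2 of the 3 values shown sit. Compound 4 `COC(=O)c1ccc(NCc2cncn2Cc2ccc(Br)cc2)cc1-c1ccccc1` differs from compound 1 by 4-bromophenyl in place of 2-methylphenyl on a saturated chain carbon bound to an aromatic nitrogen. Among the compounds with values here, no step between measured compounds is available to weigh this change, and the known results cluster at weak cytotoxicity, so the expected step is no change at the digits printed from compound 1 to compound 4 (within the scatter), none beyond the scatter. Compound 4 is accordingly estimated at 10000 nM in this assay, with a range of 3000 nM to 30000 nM.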

Compound 4, half-maximal effective concentration: > 10000 nM
Compound 4 was reported as a limit (the forecaster's own chance of this, stated with the estimate: 40%); the middle value lies on the limit itself.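

In this assay, going by these compounds alone, 4-bromophenyl in place of 2-methylphenyl on a saturated chain carbon bound to an aromatic nitrogen gives the first step at this position: a number no lower from compound 1 to compound 4 (the limit leaves the size open). Compound 4 shows only a limit, > 10000 nM. At this position, then, the change brings no cytotoxicity at smaller amounts of compound, and the series now holds a second, separate limit: the limit of > 10000 nM in this assay, at which 1 of the 4 values shown sits.

On these data alone, the size of the step remains open, as does the separate share of the departing methyl group and the entering bromine. Also open, as far as these compounds go, is how an amine or a carboxylic acid on the phenyl ring at this place would read out in this assay.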